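From chloro to methoxy on one aromatic carbon

This account rests on a few compounds, and the source may have more. Where it says the series, first, only, none or still open, it means among the compounds named here.

Within the data shown here, in a functional assay on KYSE-70 cells for antiproliferative activity against KYSE-70 cell line (Homo sapiens), read by MTT assay, with a stated time of 72 h (a lower number here means a stronger inhibitor, a higher number a weaker inhibitor), compound 2 (`O=C(Nc1cc(F)cc(F)c1)c1cc(=O)[nH]c2cc(Cl)ccc12`) gives 9000 nM and this is the only exact number so far. Compound 1 (`O=C(Nc1cc(F)cc(F)c1)c1cc(=O)[nH]c2cc(F)ccc12`) reads > 20000 nM and that is a limit of the assay, not a number. Compound 3 (`COc1ccc2c(C(=O)Nc3cc(F)cc(F)c3)cc(=O)[nH]c2c1`) keeps the rest of compound 2 and changes one group, with methoxy in place of chloro on an aromatic carbon. Among the measured compounds shown here, the one measured step that bears on this change sits on the same carbon. Chloro in place of fluoro gave an at least 2.2-fold lower number from compound 1 to compound 2 (0.34 log units; beyond the scatter) and so shows that the group on this carbon can move the number. That single step was between two halogens, however, so it gives only a loose guide for methoxy. A modest move towards a higher number, meaning a weaker inhibitor, is therefore expected, and no change beyond the scatter remains possible. The expected step is a 1.6-fold higher number from compound 2 to compound 3 (0.19 log units; within the scatter) in this estimate. For compound 3 the estimated value is 14000 nM with 6000 nM to 30000 nM as the expected range in this assay. There is also a real chance that compound 3 will turn out to give only a limit of the assay.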

Compound 3, half-maximal inhibitory concentration: > 20000 nM
Compound 3 was reported as a limit; the forecaster's own chance of this, stated with the estimate: 40%; middle value at least 1.4-fold (0.15 log units) from the limit.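

In this assay, putting methoxy in place of chloro gives an at least 2.2-fold higher number from compound 2 to compound 3 (0.34 log units; beyond the scatter), so this carbon responds to more than a swap of one halogen for another. Among these compounds, the earlier step showed only that chloro gave a lower number than fluoro; now methoxy, a non-halogen group that unlike chloro counts as a hydrogen-bond acceptor, also gives a higher number than chloro, leaving chloro as the only one of the three groups here with an exact value. The step between compound 1 and compound 3 cannot be read, because both values are limits of the assay, so fluoro and methoxy cannot be ranked against each other: the limit of > 20000 nM in this assay, at which 2 of the 3 values shown sit.

With a single exact value on this carbon, the compounds shown cannot say how far the number responds to the group placed there, or in which direction it might still fall. From the compounds shown here alone, whether a bromine atom, a methyl group or an amine on this carbon would give a lower number than compound 2, at 9000 nM, stays open.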